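Working notes: replacing 3,5-dichlorophenyl in compound 1

A few compounds are considered here, and "the series" means these few. Any claim that something is new, unique, unknown or untested is made for them only; others in the source may bear on it.

Among the measured compounds shown here, in a functional assay on SW620/5-FU cells (Homo sapiens) for cytotoxicity, read by MTT assay, with a stated time of 48 h, in the presence of a further agent that is not named here (a lower number here means that less compound is needed, a higher number that more compound is needed for the effect), compound 1 `Cn1ncc2c(-c3ccc(F)cc3)cc(NNC(=O)Nc3cc(Cl)cc(Cl)c3)nc21` gives 54300 nM, the higher of the two numbers so far. Compound 2 `Cc1nn(C)c2nc(NNC(=O)Nc3cc(Cl)nc(Cl)c3)cc(-c3ccccc3)c12` gives 22900 nM, lower by a margin beyond the scatter. Compound 3 `COc1cc(NC(=O)NNc2cc(-c3ccc(F)cc3)c3cnn(C)c3n2)cc(Cl)n1` has 2-chloro-6-methoxypyridin-4-yl in place of 3,5-dichlorophenyl on an amide-type nitrogen. For the measured compounds named here, no measured pair isolates this change, so only a small downward step in this assay is expected, within the scatter or close to it. The estimated step is a 1.7-fold lower number from compound 1 to compound 3 (0.23 log units; within the scatter). For compound 3 the expected value is 32000 nM, with a range of 11000 nM to 80000 nM.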

Compound 3, half-maximal effective concentration: 24100 nM
Compound 3: the middle estimate sits 1.3-fold (0.12 log units) above what was measured; measured number inside the range.
By their numbers in this assay, from the lowest: compounds 2 and 3 (each within the scatter of the next); then compound 1.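

In this assay, among the compounds shown here, 2-chloro-6-methoxypyridin-4-yl in place of 3,5-dichlorophenyl on the amide-type nitrogen gives a 2.3-fold lower number from compound 1 to compound 3 (0.35 log units; beyond the scatter) as the first readable step at this position. The aryl group here can therefore change, with a ring hetero atom and two hydrogen-bond acceptors entering, and the number still falls modestly. No available evidence accounts for this step.

This one pair cannot separate the contribution of the ring nitrogen from that of the methoxy group, or of the lost chlorine. As far as these compounds go, how an amine or a carboxylic acid would read on this ring remains open.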